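Swapping a Trifluoromethoxy for a Trifluoromethyl Group

A few compounds are considered here, and "the series" means these few. Any claim that something is new, unique, unknown or untested is made for them only; others in the source may bear on it.

Measured compounds:
- Compound 1, `CC(C)Cc1ccc(C(C)c2nnc3n2N=C(c2ccc(OC(F)(F)F)cc2)CS3)cc1`: 3600 nM
- Compound 2, `COc1ccc2cc(C(C)c3nnc4n3N=C(c3ccc([N+](=O)[O-])cc3)CS4)ccc2c1`: 14700 nM
- Compound 3, `COc1ccc(C2=Nn3c(nnc3C(C)c3ccc(-c4ccccc4)c(F)c3)SC2)cc1`: 4300 nM

All three share one core and were tested in a functional assay on Huh-7 cells (Homo sapiens) for inhibition, read by sulforhodamine B assay, with a stated time of 72 h; a lower number here means a stronger inhibitor, a higher number a weaker inhibitor. Compound 1 has the lowest number of the three. Compound 3 sits close to it, a gap that falls within the usual scatter of repeated measurements, so the two cannot be told apart in potency on these data. Compound 2 lies further away, beyond the scatter, so it is a weaker inhibitor than compound 1.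

The new compound, compound 4, `CC(C)Cc1ccc(C(C)c2nnc3n2N=C(c2ccc(C(F)(F)F)cc2)CS3)cc1`, differs from compound 1 in one place: trifluoromethyl in place of trifluoromethoxy on an aromatic carbon. For the measured compounds named here, no pair among the measured compounds shows this same change, so there is no measured step to lean on. The trifluoromethoxy group and the trifluoromethyl group are of similar size and the change keeps the rest of compound 1 untouched. The step of no change at the digits printed from compound 1 to compound 4 (within the scatter) is expected to be small, with no clear direction, and to stay within the scatter. Compound 4 is therefore expected to give about 3600 nM, with a range from 1500 nM to 8500 nM.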

Compound 4, half-maximal inhibitory concentration: 8400 nM
Compound 4: middle estimate off by 2.3-fold (0.37 log units), on the low side; low and high end bracket the measured number.
By their numbers in this assay, from the lowest: compounds 1, 3, 4 and 2 (each within the scatter of the next, the first and the last beyond it).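

In this assay, the exchange of trifluoromethoxy for trifluoromethyl gives a 2.3-fold higher number from compound 1 to compound 4 (0.37 log units; beyond the scatter), so this place on the aromatic ring, para to a large group, is sensitive to even a small edit. The earlier compounds shown here differ from one another in more than one place and could not isolate this position; here the rest of the molecule stays the same, and the two groups differ only by the oxygen, which is also the hydrogen-bond acceptor counted for trifluoromethoxy. Nothing measured here explains why the number rises with this change.

Going by these compounds, this single step gives the size of one exchange in one setting, so it remains open whether trifluoromethoxy is a particularly favourable group here or trifluoromethyl a particularly unfavourable one. Groups such as a chlorine atom, an amine or a carboxylic acid at the same place would help to answer that, and the same exchange on a compound with a different group in place of the isobutyl-bearing ring would show whether the step carries over.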